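Swapping the hydrazone aryl group on a shared triazine core

A few compounds are considered here, and "the series" means these few. Any claim that something is new, unique, unknown or untested is made for them only; others in the source may bear on it.

Compound 1 `NS(=O)(=O)c1ccc(Nc2nc(N/N=C/c3ccc(C(F)(F)F)cc3)nc(Nc3ccccc3)n2)cc1` and compound 2 `Cc1nn(-c2ccccc2)cc1/C=N/Nc1nc(Nc2ccccc2)nc(Nc2ccc(S(N)(=O)=O)cc2)n1` share one core and differ only at the carbon with a double bond to nitrogen. In a functional assay on RPMI-8226 cells (Homo sapiens) for inhibition, read by sulforhodamine B assay, with a stated time of 48 h (on this read-out lower numbers stand for stronger inhibition of growth and higher numbers for weaker inhibition of growth), compound 1 gives 2770 nM, and compound 2 gives 1660 nM; the two sit within the usual scatter of each other, as the step of a 1.7-fold lower number from compound 1 to compound 2 (0.22 log units; within the scatter) shows. Compound 3 `NS(=O)(=O)c1ccc(Nc2nc(N/N=C/c3ccccn3)nc(Nc3ccccc3)n2)cc1` carries the change (pyridin-2-yl in place of 3-methyl-1-phenyl-1H-pyrazol-4-yl on a carbon with a double bond to nitrogen). Going by the values given here, only that single step bears on this change, and it was small, so no step beyond the scatter is expected: a 1.3-fold higher number from compound 2 to compound 3 (0.12 log units; within the scatter). Compound 3 is therefore estimated at 2200 nM, with a range from 800 nM to 6000 nM.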

Compound 3, concentration for 50% growth inhibition: 2110 nM
Estimate against measurement, compound 3: 1.0-fold (0.02 log units) above; measured number inside the range.
By their numbers in this assay, from the lowest: compounds 2, 3 and 1 (each within the scatter of the next).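

In this assay, the single-ring pyridin-2-yl group on the carbon with a double bond to nitrogen gives a number within the scatter of both earlier compounds: a 1.3-fold higher number from compound 2 to compound 3 (0.10 log units; within the scatter), and a 1.3-fold lower number from compound 1 to compound 3 (0.12 log units; within the scatter). Three different aromatic groups at this place, with one ring or two, therefore cannot be told apart here. Nothing available explains this flat result. Still open, as far as these compounds go, is whether a group with no aromatic ring at this place, such as a longer carbon chain or a cyclohexyl group, would move the number beyond the scatter.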